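Step from compound 2 to compound 4

The source may report more compounds than this note shows. Statements on the series, on what has been measured and on what is new or still open speak of the compounds shown alone.

Measured so far in a functional assay on HL-60 cells (Homo sapiens) for inhibition, read by MTT assay, with a stated time of 72 h (on this read-out higher numbers stand for weaker inhibition and lower numbers for stronger inhibition), with these values:
compound 1 `COc1cccc(N2CCN(C(=O)c3oc(C(F)(F)F)nc3-c3cccc(F)c3)CC2)c1` gives "not active" (no number reported)
compound 2 `CCc1nc(-c2ccc(C(C)(C)C)cc2)c(C(=O)N2CCN(c3cccc(OC)c3)CC2)o1` gives "not active" (no number reported)
compound 3 `COc1cc(OC)cc(N2CCN(C(=O)c3onc(C)c3-c3ccc(F)cc3)CC2)c1` gives 475 nM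
Not yet measured: compound 4 `CCc1nc(-c2cccc(F)c2)c(C(=O)N2CCN(c3cccc(OC)c3)CC2)o1`

Compound 2 has no single number in this assay and reads "not active" (no number reported) so it cannot be ranked, and one further compound shares that kind of entry. The structural step 3-fluorophenyl in place of 4-(tert-butyl)phenyl on an aromatic carbon puts 3-fluorophenyl in place of 4-(tert-butyl)phenyl on an aromatic carbon next to the ring nitrogen. A shift towards stronger inhibition is expected in this assay but its size cannot be stated against a missing number. Compound 3 at 475 nM shows that a measurable value occurs in this set, while compound 1 at "not active" (no number reported) keeps a result without a number open. Compound 4 is expected near 1500 nM with an estimated range from 200 nM to 10000 nM if a number is reported at all.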

Compound 4, half-maximal inhibitory concentration: 201 nM
For compound 4 the middle estimate is 7.5-fold (0.87 log units) above the measured one, within the range that was stated.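

Compound 2 reads "not active" (no number reported) and compound 4 gives 201 nM in this assay so no step can be read between them. The compounds shown leave open how large the change from 4-(tert-butyl)phenyl to 3-fluorophenyl is. No evidence on a cause is at hand.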